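Three halogenated analogues and a fourth awaiting clearance data

A few compounds are considered here, and "the series" means these few. Any claim that something is new, unique, unknown or untested is made for them only; others in the source may bear on it.

Compound 1 `c1ccc(-c2ccc(Cn3nnc4ccccc43)cc2)cc1`: 12.6 mL/min/g
Compound 2 `Fc1ccc(-c2ccc(Cn3nnc4ccccc43)cc2)c(F)c1`: 6.4 mL/min/g
Compound 3 `Fc1ccc(-c2ccc(Cn3nnc4ccccc43)cc2)c(Cl)c1`: 2.6 mL/min/g

In an ADME assay on microsomes from liver (Rattus norvegicus, strain Wistar) for metabolic stability, tested at 2.5 uM (on this read-out higher numbers stand for fast clearance and lower numbers for slow clearance), compound 3 gives the lowest of the three numbers, with 2.6 mL/min/g. Its nearest neighbour is compound 2, and the step of a 2.5-fold lower number from compound 2 to compound 3 (0.39 log units; beyond the scatter) lies beyond the scatter. Against compound 1 the gap is wider: a 4.8-fold lower number from compound 1 to compound 3 (0.69 log units; beyond the scatter). The remaining step, a 2.0-fold lower number from compound 1 to compound 2 (0.29 log units; within the scatter), sits within the scatter.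

Compound 4 `FC(F)(F)c1ccc(-c2ccc(Cn3nnc4ccccc43)cc2)c(Cl)c1` differs from compound 3 in one place: trifluoromethyl in place of fluoro on an aromatic carbon. Among the compounds with values here, none of the measured steps exchanges a fluoro for a trifluoromethyl, so no step bears on this change directly. Within the data shown here, the only exchange of one group for another at this position, from compound 2 to compound 3, gave a 2.5-fold lower number from compound 2 to compound 3 (0.39 log units; beyond the scatter), and the two steps that moved the number beyond the scatter both went downward. On that basis compound 4 is expected to give a number close to or somewhat lower than compound 3 in this assay, with a step of a 1.3-fold lower number from compound 3 to compound 4 (0.11 log units; within the scatter) estimated. The value for compound 4 is estimated at 2 mL/min/g, within a range of 0.8 mL/min/g to 5 mL/min/g.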

Compound 4, intrinsic clearance in a liver preparation (reported as CLH), per the amount of preparation that the assay uses: 0.5 mL/min/g
Compound 4: middle estimate off by 4.0-fold (0.60 log units), on the high side, outside the stated range (below it).
By their numbers in this assay, from the lowest: compound 4; then compound 3; then compounds 2 and 1 (each within the scatter of the next).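

The step of a 5.2-fold lower number from compound 3 to compound 4 (0.72 log units; beyond the scatter) in this assay is the first among the compounds shown to alter only the group para to a large group: the earlier steps either brought in that fluoro together with a second halogen or left it untouched while another halogen was exchanged. With the chloro group held fixed, trifluoromethyl in place of fluoro moves the number beyond the scatter and downward, the same direction as the other steps that lie beyond the scatter, so changing this place alone is enough to shift the read-out. Nothing measured among these compounds accounts for the shift, and the data give its size and direction but no explanation.

The compounds shown leave open how other groups in this place would read, such as a nitrile, a methoxy group or an amine. They also leave open whether trifluoromethyl in place of fluoro would give a similar step on a ring that carries fluoro rather than the chloro group, or on the unsubstituted phenyl of compound 1.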